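The source may report more compounds than this note shows. Statements on the series, on what has been measured and on what is new or still open speak of the compounds shown alone.

Cancer cell growth offers a simple first test for a new series of compounds, and here the reference point is compound 1 `O=C1C=C(NCc2ccccc2)C(=O)c2c1nc1n2[C@H]2OC[C@@H](O)[C@H]2OC1`. In a functional assay on MCF7 cells (Homo sapiens) for inhibition, read by sulforhodamine B assay (a lower number here means a stronger inhibitor, a higher number a weaker inhibitor), compound 1 reads > 8000 nM. That figure is a limit of the assay and not a true number, so the starting point for this comparison has no exact value. Among the compounds with values here, the only other measured member of the series is compound 2 `COc1ccccc1NC1=CC(=O)c2c(nc3n2[C@H]2OC[C@@H](O)[C@H]2OC3)C1=O`, and in this assay compound 2 gives 6580 nM.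

The next molecule to consider is compound 3 `COc1ccccc1NC1=CC(=O)c2nc3n(c2C1=O)[C@H]1OC[C@@H](O)[C@H]1OC3`, in which 2-methoxyphenyl takes the place of benzyl on an amine nitrogen: 2-methoxyphenyl in place of benzyl on an amine nitrogen. Within the data shown here, no measured pair isolates this change, so its size must be judged with little support. The value of 6580 nM for compound 2 suggests that activity in this series may remain weak, so only a modest gain in this assay is expected, perhaps little beyond the usual scatter. The expected step is an at least 1.6-fold lower number from compound 1 to compound 3 (0.20 log units; that floor lies within the scatter). For compound 3, the estimated value is 5000 nM, with an expected range from 1500 nM to 15000 nM.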

Compound 3, half-maximal inhibitory concentration: > 4000 nM
Compound 3: no number, only a limit; the forecaster's own chance of this, stated with the estimate: 30%; the middle value is on the limit's open side.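

In this assay compound 3 gives > 4000 nM, which is a limit of the assay and not a number. Compound 1 also stands only as a limit, so no step can be read between compound 1 and compound 3. From the compounds shown here alone, whether 2-methoxyphenyl in place of benzyl on the amine nitrogen changes activity at all, and in which direction, stays open.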